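The source may hold more compounds than are shown below. What is called first, only, known or untested is meant among the compounds shown, and "the series" means these compounds.

In a functional assay on MCF7 cells (Homo sapiens) for antiproliferative activity, read by CellTiter-Glo, with a stated time of 5 days (a higher number here means a weaker inhibitor, a lower number a stronger inhibitor), compound 1 `N#Cc1ccc(/C(=C(\c2ccc(/C=C/C(=O)O)cc2)c2ccc3scnc3c2)C2CCC2)c(Cl)c1` gives 1.4 nM, while compound 2 `O=C(O)/C=C/c1ccc(/C(=C(\c2ccc(F)cc2Cl)C2CCC2)c2ccc(-c3cn[nH]c3)cc2)cc1` gives 2.9 nM, the higher of the two numbers, by a gap just beyond the usual scatter. Compound 3 `N#Cc1ccc(/C(=C(\c2ccc(/C=C/C(=O)O)cc2)c2ccc(-c3cn[nH]c3)cc2)C2CCC2)c(Cl)c1` changes compound 2 in one place, 2-chloro-4-fluorophenyl to 2-chloro-4-cyanophenyl: cyano in place of fluoro on an aromatic carbon. That same 2-chloro-4-cyanophenyl group occurs in compound 1. Compound 2 also differs from compound 1 elsewhere, so compound 1 at 1.4 nM is only a loose guide. No step beyond the scatter is expected, and the estimated change is a 1.5-fold lower number from compound 2 to compound 3 (0.16 log units; within the scatter). For compound 3 the estimated value is 2 nM, with an expected range of 0.8 nM to 5 nM.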

Compound 3, half-maximal inhibitory concentration: 2.2 nM
Beside the measured number, compound 3's estimate is 1.1-fold (0.04 log units) below it, within the range that was stated.
By their numbers in this assay, from the lowest: compounds 1, 3 and 2 (each within the scatter of the next, the first and the last beyond it).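

In this assay, cyano in place of fluoro gives a 1.3-fold lower number from compound 2 to compound 3 (0.12 log units; within the scatter), so at this position, para to a large group, the two groups cannot be told apart by this read-out. With the 2-chloro-4-cyanophenyl group held constant, 4-(1H-pyrazol-4-yl)phenyl in place of 1,3-benzothiazol-5-yl gives a 1.6-fold higher number from compound 1 to compound 3 (0.20 log units; within the scatter), so neither single change on its own steps beyond the scatter. No measurement here offers a reason for these results. From the compounds shown here alone, what an amine or a methoxy group at this position would do remains open.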